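Removing the Chloro Group from Compound 1

A few compounds are considered here, and "the series" means these few. Any claim that something is new, unique, unknown or untested is made for them only; others in the source may bear on it.

Compound 1, `O=C(Nc1cc(C(F)(F)F)cc(C(F)(F)F)c1)C1CCc2ccccc2N1C(=O)c1ccccc1Cl`, 1930 nM
Compound 2, `O=C(Nc1ccccc1O)C1CCc2ccccc2N1C(=O)c1ccc(Cl)cc1`, 13400 nM
Compound 3, `CCCCCCCCC(=O)N1c2ccccc2CCC1C(=O)Nc1ccccc1C(F)(F)F`, 6180 nM

Of the compounds shown here, three sharing one core have been tested in a functional assay on NUGC-3 cells (Homo sapiens) for cytotoxicity, read by sulforhodamine B assay, with a stated time of 72 h; on this read-out lower numbers stand for stronger inhibition of growth and higher numbers for weaker inhibition of growth. Compound 1 gives 1930 nM, the lowest of the three numbers. Compound 3 sits at a higher number, a gap beyond the scatter, and compound 2 sits higher still, also beyond the scatter. Compounds 2 and 3 differ from compound 1 in more than one place, so no single step among the measured compounds is shown, and the spread of their values says nothing direct about any one group.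

Compound 4, `O=C(Nc1cc(C(F)(F)F)cc(C(F)(F)F)c1)C1CCc2ccccc2N1C(=O)c1ccccc1`, has not been measured. It differs from compound 1 in one place: hydrogen in place of chloro on an aromatic carbon. Within the data shown here, nothing among the measured compounds isolates this change. Among the measured compounds shown here, with no comparable step available, the author expects a modest weakening in this assay, a 1.8-fold higher number from compound 1 to compound 4 (0.26 log units; within the scatter), which could also fall within the scatter. Compound 4 is estimated at 3500 nM, with a range from 1200 nM to 10000 nM.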

Compound 4, concentration for 50% growth inhibition: 1680 nM
Compound 4: the middle estimate sits 2.1-fold (0.32 log units) above what was measured; low and high end bracket the measured number.
By their numbers in this assay, from the lowest: compounds 4 and 1 (each within the scatter of the next); then compound 3; then compound 2.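

In this assay, hydrogen in place of chloro on an aromatic carbon, ortho to a large group, gives a 1.1-fold lower number from compound 1 to compound 4 (0.06 log units; within the scatter), the first step among these compounds that isolates a single place. The change from 2-chlorophenyl to phenyl therefore leaves the number within the scatter, so in this pair the chloro is not required for the growth inhibition seen, and the benzoyl compound stands level with its chlorinated partner. Nothing available explains why this exchange leaves the read-out where it is.

Still open, as far as these compounds go, is how this position would respond to other groups, such as a methoxy group, an amine or a carboxylic acid, since chloro and hydrogen are the only two compared here, and a step that stays within the scatter for these two says nothing about the rest. Also open is what the trifluoromethyl groups shared by compound 1 and compound 4 contribute, as no single-place step among the compounds shown touches that side of the amide.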